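One Group Exchanged: Expecting Little Change in Cell Growth

This account rests on a few compounds, and the source may have more. Where it says the series, first, only, none or still open, it means among the compounds named here.

In a functional assay on MCF7 cells (Homo sapiens) for antiproliferative activity, read by sulforhodamine B assay (on this read-out lower numbers stand for stronger inhibition and higher numbers for weaker inhibition), compound 1 (`O=C1NC(=O)c2ccc(-n3cccc3)cc2/C1=C/Nc1ccc(CN2CCCCC2)cc1`) gives 2100 nM, and compound 2 (`CN1CCN(c2ccc(N/C=C3\C(=O)NC(=O)c4ccc(-c5ccsc5)cc43)cc2)CC1`) gives 2300 nM. These two values lie within the usual scatter of repeated measurements, so neither compound can be ranked above the other. The two compounds also differ in more than one place, and so their values cannot be tied to any single group.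

Compound 3 (`O=C1NC(=O)c2ccc(-c3ccsc3)cc2/C1=C/Nc1ccc(CN2CCCCC2)cc1`) has not yet been measured. It differs from compound 2 in one place: (piperidin-1-yl)methyl in place of 4-methylpiperazin-1-yl on an aromatic carbon. Within the data shown here, the incoming group is not new to this small set, since compound 1 carries it and gives 2100 nM, which is the only guide available.

A small step with no firm direction is therefore expected in this assay, one that stays within the scatter. The estimated step is a 1.2-fold lower number from compound 2 to compound 3 (0.06 log units; within the scatter). With so few data, the expected range must be wide. For compound 3 the estimated value is 2000 nM, with a range from 800 nM to 5000 nM.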

Compound 3, half-maximal inhibitory concentration: 3400 nM
Compound 3: the middle estimate sits 1.7-fold (0.23 log units) below what was measured; the measured number falls inside the stated range.
By their numbers in this assay, from the lowest: compounds 1, 2 and 3 (each within the scatter of the next).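

In this assay the exchange of 4-methylpiperazin-1-yl for (piperidin-1-yl)methyl, on an aromatic carbon para to a large group, gives a step that cannot be told from the usual scatter (a 1.5-fold higher number from compound 2 to compound 3 (0.17 log units; within the scatter)), so this read-out shows no clear effect from that exchange, although the entering group carries one hetero atom in its ring and the leaving group two. Compound 1 and compound 2 could not show this, as they differ in more than one place, but compound 3 differs from each of them in one place only, and so it also opens a view of the other site: thiophen-3-yl in place of 1H-pyrrol-1-yl also stays within the scatter (a 1.6-fold higher number from compound 1 to compound 3 (0.21 log units; within the scatter)). Nothing available here explains why either exchange leaves the number within the scatter.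

From the compounds shown here alone, both groups compared at the first site hold a six-membered non-aromatic ring, so it remains open whether a group without such a ring, such as a dimethylamino group or a carboxylic acid, would behave the same way. Going by these compounds, at the second site, it remains open whether a plain phenyl ring would also stay within the scatter.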